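From a Silent Dihydroxy Compound to a Trifluoromethyl Analogue

The source may hold more compounds than are shown below. What is called first, only, known or untested is meant among the compounds shown, and "the series" means these compounds.

Compound 1 `COc1ccc(CNc2ncnc3c2ncn3[C@@H]2O[C@H](CO)[C@@H](O)[C@H]2O)c(OC)c1`: "not determined" (no result reported)
Compound 2 `OC[C@H]1O[C@@H](n2cnc3c(NCc4cc(O)cc(O)c4)ncnc32)[C@H](O)[C@@H]1O`: > 166000 nM

In a functional assay on G-361 cells (Homo sapiens) for antiproliferative activity, with a stated time of 72 h (on this read-out lower numbers stand for stronger inhibition and higher numbers for weaker inhibition), compound 2 gives > 166000 nM as a limit of the assay and not a number. Compound 1 stands as "not determined" (no result reported) in this assay and so offers no comparison. Among the compounds with values here, compound 2 therefore has no exact position on the scale, and no measured step between the two compounds is available to set the size of the next change.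

The next compound to be tested is compound 3 `OC[C@H]1O[C@@H](n2cnc3c(NCc4cccc(C(F)(F)F)c4)ncnc32)[C@H](O)[C@@H]1O` and it keeps the shared core. The change lies on a saturated chain carbon bound to a nitrogen on an aromatic ring, where 3-(trifluoromethyl)phenyl comes in place of 3,5-dihydroxyphenyl 3-(trifluoromethyl)phenyl in place of 3,5-dihydroxyphenyl on a saturated chain carbon bound to a nitrogen on an aromatic ring and leaves the rest of the structure untouched.

The only anchor for the expectation is compound 2 with its limit of > 166000 nM in this assay as the reference. The step of an at least 20-fold lower number from compound 2 to compound 3 (1.31 log units; beyond the scatter) is expected to run toward stronger inhibition and well beyond the scatter. For compound 3 the estimated half-maximal inhibitory concentration is 8000 nM with an expected range from 1500 nM to 60000 nM in repeated measurements.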

Compound 3, half-maximal inhibitory concentration: > 166000 nM
Compound 3 ended at the assay's limit; the forecaster's own chance of this, stated with the estimate: 20%; middle value at least 20-fold (1.31 log units) away from the limit.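

In this assay compound 3 gives > 166000 nM, a limit of the assay and not a number. Compound 2 is also held only by a limit, so the step between compound 2 and compound 3 cannot be read. The compounds shown leave open where either compound truly stands and whether any other group in this place would give a readable number.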